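Swapping bromo for methyl on the sulfanyl ring

The source may hold more compounds than are shown below. What is called first, only, known or untested is meant among the compounds shown, and "the series" means these compounds.

Measured compounds:
compound 1 `O=C(/C(=C\c1ccc(Cl)cc1)Sc1ccc(Br)cc1)c1ccc(Br)cc1`: 1000 nM
compound 2 `COc1cc(/C=C(/Sc2ccc(Br)cc2)C(=O)c2ccc(Br)cc2)ccc1O`: 1000 nM
compound 3 `O=C(/C(=C\c1ccc(Oc2ccccc2)cc1)Sc1ccc(Br)cc1)c1ccc(Br)cc1`: 50000 nM

In a functional assay on DU-145 cells (Homo sapiens) for inhibition, read by trypan blue exclusion, with a stated time of 96 h (a lower number here means a stronger inhibitor of growth, a higher number a weaker inhibitor of growth), compound 1 gives 1000 nM, level with compound 2 and together the lowest of the three numbers; the furthest value belongs to compound 3, with a 50-fold higher number from compound 1 to compound 3 (1.70 log units; beyond the scatter). Compound 4 `Cc1ccc(S/C(=C/c2ccc(Cl)cc2)C(=O)c2ccc(Br)cc2)cc1` differs from compound 1 by methyl in place of bromo on an aromatic carbon. Among the measured compounds shown here, no measured step touches this aromatic carbon para to a large group. The steps seen are no change at the digits printed from compound 1 to compound 2 (within the scatter), a change of aryl on the double-bonded chain carbon, and a 50-fold higher number from compound 1 to compound 3 (1.70 log units; beyond the scatter), a bulkier group entering elsewhere. Bromo to methyl is a small exchange of one heavy atom for one, so compound 4 is expected to give 1500 nM, between 500 nM and 5000 nM, a step of a 1.5-fold higher number from compound 1 to compound 4 (0.18 log units; within the scatter) that should stay near the scatter.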

Compound 4, concentration for 50% growth inhibition: 10000 nM
Compound 4: the middle estimate sits 6.7-fold (0.82 log units) below what was measured; measured number outside the range, above it.
By their numbers in this assay, from the lowest: compounds 1 and 2 (each within the scatter of the next); then compound 4; then compound 3.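

In this assay, methyl in place of bromo on the sulfanyl ring gives a 10-fold higher number from compound 1 to compound 4 (1.00 log units; beyond the scatter), so this position responds beyond the scatter to an exchange of one heavy atom for one, with no hydrogen-bond donor or acceptor on either side. The earlier compounds shown here showed a step beyond the scatter only with phenoxy entering on a different ring. Nothing measured here accounts for this step. The compounds shown leave open how chloro, methoxy or an amine would read on this ring, and whether the bromo on the other ring responds to methyl in the same way.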